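The compounds below may be only part of what the source reports. "The series", "measured", "known", "first", "only" and "open" are said of these compounds alone.

Measured compounds:
compound 1 `O=c1c(-c2ccc(O)cc2)coc2cc(CC3OC(CO)C(O)C(O)C3O)ccc12` gives 0%
compound 2 `O=c1c(-c2ccc(O)cc2)coc2cc(OCCCCCCBr)ccc12` gives 95.7%
compound 3 `O=c1c(-c2ccc(O)cc2)coc2cc(OCCC3OCCCO3)ccc12` gives 88.5%

All three were tested in a functional assay on mitochondria (Cricetulus griseus) for inhibition of Monoamine oxidase (Homo sapiens), tested at 9 uM; a higher number here means a stronger effect of the compound at the concentration tested, a lower number a weaker effect. Compound 2 and compound 3 cannot be separated on these numbers, since a number 7.2 percentage points lower from compound 2 to compound 3 (within the scatter). Within the data shown here, compound 1, which carries a sugar-derived group on a carbon instead of an ether chain on the shared core, gives a reading far below that of compound 2, beyond the scatter; no single-place step links compound 1 to the others, so only the two values themselves are spoken of here.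

Compound 4 `O=C(O)CCCCCCCCCOc1ccc2c(=O)c(-c3ccc(O)cc3)coc2c1` is the unmeasured compound. It differs from compound 2 as follows: 3-carboxypropyl in place of bromo on a saturated chain carbon, six bonds along the chain from an oxygen on an aromatic ring. The ether chain on the core is kept, as it is in compound 2 and compound 3, and only the end of that chain is altered.

Among the measured compounds shown here, the one measured step that bears on this change is the step from compound 2 to compound 3, where the end of the same chain was exchanged and the reading moved only by a number 7.2 percentage points lower from compound 2 to compound 3 (within the scatter). Exchanging the chain end once more, this time for 3-carboxypropyl, is therefore expected to leave this assay roughly where compound 2 stands, with at most a small drop, so the step to compound 4 is expected to read a number 10.7 percentage points lower from compound 2 to compound 4 (beyond the scatter). Compound 4 is thus estimated at 85%, with a range from 60% to 97%.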

Compound 4, a percentage reported as inhibition, at one concentration (the size of the read-out at that concentration, not a potency): 95%
For compound 4 the middle estimate is 10 percentage points below the measured one; the measured number falls inside the stated range.
By their numbers in this assay, from the lowest: compound 1; then compounds 3, 4 and 2 (each within the scatter of the next).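

At the end of the ether chain, on a saturated chain carbon six bonds along the chain from an oxygen on an aromatic ring, 3-carboxypropyl can take the place of bromo without a change that can be told apart in this assay, as the record shows a number 0.7 percentage points lower from compound 2 to compound 4 (within the scatter). The earlier compounds shown here had not included a chain end with a hydrogen-bond donor, and this new end also leaves the reading inseparable from that of the ring-bearing chain, with a number 6.5 percentage points higher from compound 3 to compound 4 (within the scatter). No measurement at hand explains why these different chain ends give readings within the scatter of one another.

The compounds shown leave open whether a shorter chain ending in a carboxylic acid, or a chain of the same length ending in an amine, would hold the reading in this assay. They also leave open whether compound 2, compound 3 and compound 4 would differ in the size of their effect at other concentrations, since each reading shows the effect at one concentration only.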